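Ester variants of the phenol in the lymphocyte cytotoxicity series

A few compounds are considered here, and "the series" means these few. Any claim that something is new, unique, unknown or untested is made for them only; others in the source may bear on it.

Compound 1 `COC(=O)/C(=C\c1ccc(O)cc1)Sc1ccnc2cc(Cl)ccc12` carries a free phenol; in an ADME assay on cells (Lymphocyte, Homo sapiens) for cytotoxicity, read by MTT assay, with a stated time of 48 h (on this read-out lower numbers stand for stronger inhibition and higher numbers for weaker inhibition), compound 1 gives 33700 nM. Compound 2 `COC(=O)/C(=C\c1ccc(OC(=O)c2ccc(OC)cc2)cc1)Sc1ccnc2cc(Cl)ccc12` gives 63500 nM, the highest of the two numbers read, and a 1.9-fold higher number from compound 1 to compound 2 (0.28 log units; within the scatter). Compound 3 `COC(=O)/C(=C\c1ccc(OC(=O)c2ccccc2OC)cc1)Sc1ccnc2cc(Cl)ccc12` reaches only a limit, > 100000 nM; a limit of this kind is the limit of > 100000 nM in this assay, at which 1 of the 3 values shown sits. Against that, an at least 2.9-fold higher number from compound 1 to compound 3 (0.47 log units; beyond the scatter) and an at least 1.5-fold higher number from compound 2 to compound 3 (0.19 log units; that floor lies within the scatter). Compound 4 `COC(=O)/C(=C\c1ccc(OC(=O)c2cccc(OC)c2OC)cc1)Sc1ccnc2cc(Cl)ccc12` is not yet measured; it differs from compound 2 by 2,3-dimethoxyphenyl in place of 4-methoxyphenyl on a carbonyl carbon. The nearest measured step runs from compound 2 to compound 3, where a methoxy also enters the 2-position. For compound 4 a step toward a higher number, possibly to the limit again, is expected: a 1.4-fold higher number from compound 2 to compound 4 (0.15 log units; within the scatter). Compound 4 is therefore estimated at 90000 nM, within 40000 nM to 250000 nM.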

Compound 4, half-maximal inhibitory concentration: 86600 nM
For compound 4 the middle estimate is 1.0-fold (0.02 log units) above the measured one, within the range that was stated.
By their numbers in this assay, from the lowest: compounds 1, 2 and 4 (each within the scatter of the next, the first and the last beyond it). At a limit, above all of these: compound 3.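

Compound 4 carries 2,3-dimethoxyphenyl in place of 4-methoxyphenyl on a carbonyl carbon, and the step is a 1.4-fold higher number from compound 2 to compound 4 (0.13 log units; within the scatter), so the two esters are not separated. Unlike compound 2, compound 4 gives a measured number beyond the scatter of the free phenol (a 2.6-fold higher number from compound 1 to compound 4 (0.41 log units; beyond the scatter)), so the two measured esters do not agree in their separation from compound 1. Compound 3 stands at a limit: the limit of > 100000 nM in this assay, at which 1 of the 4 values shown sits. The step that this limit allows is an at least 1.1-fold lower number from compound 3 to compound 4 (0.06 log units; that floor lies within the scatter).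

Going by these compounds, whether an amine or a carboxylic acid in place of methoxy on this aromatic ring would shift the number in this assay stays open. On these data alone, the effect of a longer chain in place of methoxy stays open as well.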